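Aryl swap on the carbonyl within a trimethoxyphenyl pyrazole series

The source may report more compounds than this note shows. Statements on the series, on what has been measured and on what is new or still open speak of the compounds shown alone.

Compound 1 `COc1cc(-c2cc(/C=C/C(=O)c3ccc(Cl)c(Cl)c3)[nH]n2)cc(OC)c1OC` stands highest of the three numbers in a functional assay on SK-MEL-28 cells (Homo sapiens) for cytotoxicity, read by sulforhodamine B assay, with a stated time of 48 h, tested at 1 uM (on this read-out higher numbers stand for a weaker effect at the one concentration tested and lower numbers for a stronger effect), giving 114%. Compound 2 `COc1ccc(-c2cc(/C=C/C(=O)c3ccc(N)cc3)[nH]n2)cc1OC` gives 89% in this assay, a gap beyond the scatter, and compound 3 `COc1ccc(-c2cc(/C=C/C(=O)c3cc(OC)c(OC)c(OC)c3)[nH]n2)cc1OC` gives 89%, the same gap. The two lower values share a methoxylated aryl on the carbonyl, whereas compound 1 carries chlorines there. Compound 4 `COc1ccc(C(=O)/C=C/c2cc(-c3cc(OC)c(OC)c(OC)c3)n[nH]2)cc1OC` keeps the core of compound 1 and changes one place: 3,4-dimethoxyphenyl in place of 3,4-dichlorophenyl on a carbonyl carbon. Going by the values given here, no measured pair of this kind is available, so the size of the step rests on the pattern above. The step is expected to fall beyond the scatter, toward a stronger effect, with a number 24 percentage points lower from compound 1 to compound 4 (beyond the scatter). Compound 4 is therefore estimated at 90%, within 72% to 108%, in this assay.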

Compound 4, a percentage reported as activity, at one concentration (the size of the read-out at that concentration, not a potency): 96%
Beside the measured number, compound 4's estimate is 6 percentage points below it; measured number inside the range.
By their numbers in this assay, from the lowest: compounds 2, 3 and 4 (each within the scatter of the next); then compound 1.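

Going by these compounds alone, with the core of compound 1 held fixed, this is the only single-place change so far, and it shows that the aryl group on a carbonyl carbon affects the read-out. In this assay, 3,4-dimethoxyphenyl in place of 3,4-dichlorophenyl gives a number 18 percentage points lower from compound 1 to compound 4 (beyond the scatter), a modest step toward a stronger effect. No available data explain this step.

Still open, going by these compounds, is whether a nitrile or a carboxylic acid on that aryl ring would move the read-out further. On these data alone, whether the step holds at other concentrations also remains open.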